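The compounds below may be only part of what the source reports. "The series", "measured", "known", "first", "only" and "open" are said of these compounds alone.

Measured compounds:
- compound 1, `O=C(Nc1ccccc1)Nc1cccc(CNc2nccnc2Cl)c1`: in a functional assay on HepG2 cells (Homo sapiens) for antiproliferative activity, read by MTT assay, with a stated time of 48 h (on this read-out lower numbers stand for stronger inhibition and higher numbers for weaker inhibition), compound 1 gives 15600 nM.
- compound 2, `O=C(Nc1cccc(CNc2nccnc2Cl)c1)NC1CCCCC1`: in this assay compound 2 gives only a limit of the assay, > 40000 nM.
- compound 3, `O=C(Nc1cccc(CNc2nccnc2Cl)c1)Nc1ccc(Cl)cc1Br`: in this assay compound 3 gives 6720 nM.

Compound 1 has the highest of the two numbers measured; the nearest is compound 3, reached by a 2.3-fold lower number from compound 1 to compound 3 (0.37 log units; beyond the scatter), and the remaining value is the limit at which compound 2 sits (the limit of > 40000 nM in this assay, at which 1 of the 3 values shown sits). Replacing phenyl with cyclohexyl gives an at least 2.5-fold higher number from compound 1 to compound 2 (0.40 log units; beyond the scatter), and replacing cyclohexyl with the halogenated ring gives an at least 5.9-fold lower number from compound 2 to compound 3 (0.77 log units; beyond the scatter).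

Compound 4 is `O=C(Nc1cccc(CNc2nccnc2Cl)c1)Nc1ccc(Cl)cc1Cl`. Its difference from compound 1 is 2,4-dichlorophenyl in place of phenyl on an amide-type nitrogen. Among the compounds with values here, the step that bears most closely on it is the one to compound 3, a 2.3-fold lower number from compound 1 to compound 3 (0.37 log units; beyond the scatter), where a 2-bromo-4-chlorophenyl ring also replaced the plain phenyl; compound 2 shows that leaving the aromatic ring altogether worsens the number. A modest lowering of the number in this assay, close in size to that seen for compound 3, is therefore expected for compound 4, as a 2.0-fold lower number from compound 1 to compound 4 (0.29 log units; within the scatter).

Compound 4 is estimated at 8000 nM, with a range from 4000 nM to 16000 nM.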

Compound 4, half-maximal inhibitory concentration: 7230 nM
Compound 4: the middle estimate sits 1.1-fold (0.04 log units) above what was measured; the range from low to high includes it.
By their numbers in this assay, from the lowest: compounds 3 and 4 (each within the scatter of the next); then compound 1. At a limit, above all of these: compound 2.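

Working notes: in this assay, the step of a 1.1-fold higher number from compound 3 to compound 4 (0.03 log units; within the scatter) leaves the two halogenated rings indistinguishable, so at this position the number does not separate chloro from bromo on an aromatic carbon. The lowering against plain phenyl also holds with no bromo present, at a 2.2-fold lower number from compound 1 to compound 4 (0.33 log units; beyond the scatter), which means it is not specific to the 2-bromo-4-chlorophenyl ring of compound 3. The step of an at least 5.5-fold lower number from compound 2 to compound 4 (0.74 log units; beyond the scatter) extends the gap from cyclohexyl to a second halogenated ring, though it rests on compound 2, which stands at a limit and not at a number: the limit of > 40000 nM in this assay, at which 1 of the 4 values shown sits.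

Open, from the compounds shown here alone, is whether a phenyl ring carrying a single chloro keeps this lowering, or whether both halogens are needed. Also open, going by these compounds, is how methoxy or trifluoromethyl would read in place of these halogens.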